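The source may report more compounds than this note shows. Statements on the series, on what has been measured and on what is new or still open speak of the compounds shown alone.

Two compounds of the series have been run in a functional assay on MT2 cells (Homo sapiens) for cytotoxicity, read by MTT assay; a higher number here means that more compound is tolerated, a lower number that less compound is tolerated. Compound 1, `CC(C)=CCOc1cc(Nc2ncccn2)ccc1Cl`, gives 2500 nM in this assay. Compound 2, `CC(C)=CCOc1cc(Nc2nccc(C)n2)ccc1Cl`, gives < 200 nM in this assay, and that value is a limit of the measurement, not a number. The step of an at least 12-fold lower number from compound 1 to compound 2 (1.09 log units; beyond the scatter) is thus only a floor on the true change, and compound 2 stands at the limit of < 200 nM in this assay, at which 1 of the 2 values shown sits.

Compound 3, `CC(C)=CCOc1cc(Nc2nccc(C(F)(F)F)n2)ccc1Cl`, follows from compound 2 by trifluoromethyl in place of methyl on an aromatic carbon. Among the compounds with values here, no measured step swaps a methyl for a trifluoromethyl on the shared core, so the only step that touches this region is an at least 12-fold lower number from compound 1 to compound 2 (1.09 log units; beyond the scatter), which concerns a different group and does not settle the present change. With compound 2 already at the limit, a further drop for compound 3 would stay hidden, and a rise would need to be large to show. Compound 3 is therefore expected to give about 150 nM in this assay, between 40 nM and 600 nM, so that the step that the limit leaves unreadable from compound 2 to compound 3 is estimated to fall within the scatter.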

Compound 3, half-maximal cytotoxic concentration: 2500 nM
Compound 3: the middle estimate sits 17-fold (1.22 log units) below what was measured; measured number above the stated range.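

Up to this point, the only change at this aromatic carbon next to the ring nitrogen had been methyl in place of hydrogen, which left open whether any substituent there would lower the number in this assay. Compound 3 answers this for trifluoromethyl, with no change at the digits printed from compound 1 to compound 3 (within the scatter), so putting a group at this place does not by itself lower the number. Exchanging the methyl for trifluoromethyl gives an at least 12-fold higher number from compound 2 to compound 3 (1.09 log units; beyond the scatter), so among the compounds shown the drop belongs to the methyl alone, and the size of this step is only a floor on the true change: the limit of < 200 nM in this assay, at which 1 of the 3 values shown sits.

With just three groups at this place, the result does not show whether the low number of compound 2 is particular to methyl or would also appear with an ethyl, a methoxy group, a chlorine or an amine. From the compounds shown here alone, how far the true value of compound 2 lies beyond its limit also stays open, and so does whether the same exchange would behave alike on a core with a different chain in place of the prenyl ether.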